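Removing a Methoxy Group from a Benzamide Cell Growth Inhibitor

This account rests on a few compounds, and the source may have more. Where it says the series, first, only, none or still open, it means among the compounds named here.

Measured so far:
Compound 1 `Cc1ccc(NC(=O)c2ccc(OCCCCn3ccnc3)c(Br)c2)cc1Nc1nccc(-c2cccnc2)n1`: 31800 nM
Compound 2 `COc1ccc(C(=O)Nc2ccc(C)c(Nc3nccc(-c4cccnc4)n3)c2)cc1OCCCCn1ccnc1`: 18700 nM
Compound 3 `Cc1ccc(OCCCCn2ccnc2)c(C(=O)Nc2ccc(C)c(Nc3nccc(-c4cccnc4)n3)c2)c1`: 48600 nM

Of the compounds shown here, three sharing one core have been tested in a functional assay on K-562R cells (Homo sapiens) for cytotoxicity, read by XTT assay, with a stated time of 24 h; a higher number here means a weaker inhibitor, a lower number a stronger inhibitor. Compound 2 gives the lowest of the three numbers; its nearest neighbour is compound 1, and that gap lies within the usual scatter, while its gap to compound 3 lies beyond it. Compound 4 `Cc1ccc(NC(=O)c2cccc(OCCCCn3ccnc3)c2)cc1Nc1nccc(-c2cccnc2)n1` has not yet been measured. It differs from compound 2 by one change: hydrogen in place of methoxy on an aromatic carbon. Among the measured compounds shown here, no pair of measured compounds differs by just such a change, so there is no measured step to lean on. A change of this size is expected to move the number little, with the step of a 1.4-fold higher number from compound 2 to compound 4 (0.14 log units; within the scatter) expected to stay near the scatter, if anything slightly weakening. Compound 4 is therefore estimated at 26000 nM, within a range of 10000 nM to 65000 nM.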

Compound 4, half-maximal inhibitory concentration: 63400 nM
Estimate against measurement, compound 4: 2.4-fold (0.39 log units) below, within the range that was stated.
By their numbers in this assay, from the lowest: compounds 2, 1, 3 and 4 (each within the scatter of the next, the first and the last beyond it).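

Replacing the methoxy group with hydrogen, ortho to the 4-(1H-imidazol-1-yl)butoxy group, produces in this assay a 3.4-fold higher number from compound 2 to compound 4 (0.53 log units; beyond the scatter) and so shows that this position is not indifferent to what it carries. Among the compounds shown here, the methoxy group is worth a modest amount of cell growth inhibition here, a first measured step for this change. Nothing available explains the step.

On these data alone, it remains open whether another group at this position, such as an ethoxy group, an amine or a carboxylic acid, would match compound 2 or improve on it.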